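This account rests on a few compounds, and the source may have more. Where it says the series, first, only, none or still open, it means among the compounds named here.

Measured in a physicochemical assay for lipophilicity, read by LC-MS, in phosphate buffer, measured as octanol-water partition, at pH 7.4, tested at 66.7 uM; a lower number here means a more polar compound, a higher number a more lipophilic compound:
Compound 1 `CN1CCN(c2ccc(Nc3nccc(-c4cccc(Cl)c4)n3)cc2C(F)(F)F)CC1` gives > 6, which is a limit of this measurement rather than an exact number.
Compound 2 `CN1CCN(c2ccc(Nc3nccc(-c4cccnc4)n3)cc2C(F)(F)F)CC1` gives 3.53.

Compound 1 therefore stands only at a limit here, with no exact number behind it. Compound 3 `CN1CCN(c2ccc(Nc3nccc(-c4cccc([N+](=O)[O-])c4)n3)cc2C(F)(F)F)CC1` differs from compound 1 by nitro in place of chloro on an aromatic carbon. Among the compounds with values here, the single measured step, a number at least 2.47 log units lower from compound 1 to compound 2 (beyond the scatter), exchanges the whole 3-chlorophenyl ring for pyridin-3-yl, a larger change than the one leading to compound 3, so it bears on it only loosely. A moderate downward step is expected, a number at least 0.70 log units lower from compound 1 to compound 3 (beyond the scatter). For compound 3 the estimated value is 5.3, within a range from 4.5 to 6.1.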

Compound 3, distribution coefficient: 4.5
Estimate against measurement, compound 3: 0.80 log units above; the range from low to high includes it.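

With the phenyl ring kept, nitro in place of chloro on an aromatic carbon already gives a number at least 1.50 log units lower from compound 1 to compound 3 (beyond the scatter) in this assay. The value of compound 1 is a limit, so this step has no exact size: the limit of > 6 in this assay, at which 1 of the 3 values shown sits.

The ring itself also counts, since 3-nitrophenyl in place of pyridin-3-yl gives a number 0.97 log units higher from compound 2 to compound 3 (beyond the scatter). The compounds shown leave open where an amine or a carboxylic acid on this aromatic carbon would fall. They also leave open how a methoxy group would compare with chloro and nitro.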